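A few compounds are considered here, and "the series" means these few. Any claim that something is new, unique, unknown or untested is made for them only; others in the source may bear on it.

Measured so far in a functional assay on SK-OV-3 cells (Homo sapiens) for inhibition, read by CCK-8 assay, with a stated time of 70 h; a lower number here means a stronger inhibitor, a higher number a weaker inhibitor:

Compound 1, `O=[N+]([O-])c1ccc(COc2ccc(OCCOCCNC3CCCC3)cc2)cc1`, gives 20300 nM.
Compound 2, `Nc1ccccc1COc1ccc(OCCOCCNC2CCCC2)cc1`, gives 14000 nM.
Compound 3, `O=Cc1ccc(COc2ccc(OCCOCCNC3CCCC3)cc2)cc1`, gives 45000 nM.

Compound 3 stands highest of the three numbers: a 2.2-fold higher number from compound 1 to compound 3 (0.35 log units; beyond the scatter) and a 3.2-fold higher number from compound 2 to compound 3 (0.51 log units; beyond the scatter), both modest. Compound 4, `CCOc1ccc(OCCOCCNC2CCCC2)cc1`, differs from compound 3 in one place: methyl in place of 4-formylphenyl on a saturated chain carbon bound to an oxygen on an aromatic ring. For the measured compounds named here, no measured step removes the aryl group itself; the measured steps only exchange groups on it, and each of those moved the number by a modest amount. On this basis the change from compound 3 to compound 4 is expected to shift the number by no more than a modest amount, in either direction, as a 1.1-fold higher number from compound 3 to compound 4 (0.05 log units; within the scatter). For compound 4 in this assay the estimate is 50000 nM, in the range 15000 nM to 160000 nM.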

Compound 4, half-maximal inhibitory concentration: 90500 nM
Compound 4: the middle estimate sits 1.8-fold (0.26 log units) below what was measured; measured number inside the range.
By their numbers in this assay, from the lowest: compounds 2 and 1 (each within the scatter of the next); then compounds 3 and 4 (each within the scatter of the next).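

In this assay, for the compounds shown here, compound 4 is the first to carry methyl instead of an aryl group on a saturated chain carbon bound to an oxygen on an aromatic ring. Against 4-formylphenyl, this exchange stays within the scatter (a 2.0-fold higher number from compound 3 to compound 4 (0.30 log units; within the scatter)), but against the other two aryl groups it goes beyond the scatter (a 6.5-fold higher number from compound 2 to compound 4 (0.81 log units; beyond the scatter) and a 4.5-fold higher number from compound 1 to compound 4 (0.65 log units; beyond the scatter)). Nothing given here accounts for this contrast. Still open, on these data alone, is how a longer chain, or an amine or carboxylic acid carried on such a chain, would read at this place.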